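Iodo in place of methoxy: notes on compound 3

The source may hold more compounds than are shown below. What is called first, only, known or untested is meant among the compounds shown, and "the series" means these compounds.

compound 1 `COc1ccc(/C=C(/Sc2ccc(Br)cc2)C(=O)c2ccc(Br)cc2)cc1` gives 25000 nM in the first measurement
compound 2 `COc1ccc(/C=C(/SCc2ccc(F)cc2)C(=O)c2ccc(Br)cc2)cc1` gives 50000 nM in the second measurement
compound 3 `O=C(/C(=C\c1ccc(I)cc1)Sc1ccc(Br)cc1)c1ccc(Br)cc1` is not yet measured

Within the data shown here, in a functional assay on DU-145 cells (Homo sapiens) for inhibition, read by trypan blue exclusion, with a stated time of 96 h (a higher number here means a weaker inhibitor of growth, a lower number a stronger inhibitor of growth), only two compounds carry numbers, and the single step is a 2.0-fold higher number from compound 1 to compound 2 (0.30 log units; within the scatter) so compound 1 holds no separate rank on these numbers. Compound 3 keeps the core of compound 1 and changes one group: iodo in place of methoxy on an aromatic carbon with iodo in place of methoxy on an aromatic carbon. Among the measured compounds shown here, the measured step lies on the sulfur, as 4-fluorobenzyl in place of 4-bromophenyl, so no measured step tests this place. The estimate therefore starts from compound 1 at 25000 nM and no step beyond the scatter is expected in this assay for now. The expected step is a 1.2-fold higher number from compound 1 to compound 3 (0.08 log units; within the scatter) by this estimate. For compound 3 the expected value is 30000 nM with an estimated range from 9000 nM to 90000 nM in these notes.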

Compound 3, concentration for 50% growth inhibition: 1000 nM
Estimate against measurement, compound 3: 30-fold (1.48 log units) above; the measured number lies below the stated range.
By their numbers in this assay, from the lowest: compound 3; then compounds 1 and 2 (each within the scatter of the next).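

In this assay, among these compounds, the change from 4-methoxyphenyl to 4-iodophenyl gives a 25-fold lower number from compound 1 to compound 3 (1.40 log units; beyond the scatter), so this place on the shared core is sensitive to its substituent, whereas the one earlier step, on the sulfur, stayed within the scatter. The change is confined to one group on an aromatic carbon, para to a large group, and the rest of the structure stays the same, so the large step belongs to iodo in place of methoxy. No available data bear on why this exchange has so large an effect.

Still open, going by these compounds, is whether other groups at this place, such as chloro, an amine or a carboxylic acid, would read like iodo or like methoxy. Also open, on these data alone, is whether iodo in place of methoxy gives a similar step with the 4-fluorobenzyl group on the sulfur.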